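A few compounds are considered here, and "the series" means these few. Any claim that something is new, unique, unknown or untested is made for them only; others in the source may bear on it.

In a functional assay on HeLa S3 cells (Homo sapiens) for antiproliferative activity, read by XTT assay, with a stated time of 72 h (a higher number here means a weaker inhibitor, a lower number a stronger inhibitor), compound 1 `Cc1nc(N)c2c(-c3ccco3)cn([C@@H]3O[C@H](CO)[C@@H](O)[C@H]3O)c2n1` gave only a limit of the assay, > 20000 nM. Compound 2 `Cc1nc(N)c2c(-c3cc4ccccc4o3)cn([C@@H]3O[C@H](CO)[C@@H](O)[C@H]3O)c2n1` likewise gave only a limit, > 20000 nM. Compound 3 `CNc1ncnc2c1c(-c1cc3ccccc3o1)cn2[C@@H]1O[C@H](CO)[C@@H](O)[C@H]1O` also returned only a limit, > 20000 nM. The change from compound 2 to compound 1 is furan-2-yl in place of 1-benzofuran-2-yl on an aromatic carbon, and it made a step that the two limits leave unreadable from compound 2 to compound 1. The same change leads from compound 3 to compound 4 `CNc1ncnc2c1c(-c1ccco1)cn2[C@@H]1O[C@H](CO)[C@@H](O)[C@H]1O`, namely (furan-2-yl in place of 1-benzofuran-2-yl on an aromatic carbon), which is still to be measured in this assay. The cores of compound 3 and compound 2 differ, but that difference is not broken down here. Going by the values given here, the only evidence on the measured step is the limit of > 20000 nM in this assay, at which 3 of the 3 values shown sit. For compound 4 the expected step is a step that the limit leaves unreadable from compound 3 to compound 4, which rests on a step that the two limits leave unreadable from compound 2 to compound 1 and on (the limit of > 20000 nM in this assay, at which 3 of the 3 values shown sit). Compound 4 is therefore estimated at 40000 nM, most likely reported again only as a limit.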

Compound 4, half-maximal inhibitory concentration: 5000 nM
Beside the measured number, compound 4's estimate is 8.0-fold (0.90 log units) above it; measured number outside the range, below it.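

In this assay, furan-2-yl in place of 1-benzofuran-2-yl on the core of compound 3 gave an at least 4.0-fold lower number from compound 3 to compound 4 (0.60 log units; beyond the scatter), a size that is only a lower bound set by a limit at its start: the limit of > 20000 nM in this assay, at which 3 of the 4 values shown sit. On the core of compound 2 the same change ended in only a limit, with compound 1 at > 20000 nM, so that step cannot be read. The gain is therefore shown on one core only, and the compounds neither confirm nor refute that it carries over to the other.

The compounds shown leave open how a thiophen-2-yl group, a phenyl group or an amine on that aromatic carbon would read in this assay. They also leave open which part of the difference between the two cores matters.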